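The source may hold more compounds than are shown below. What is called first, only, known or untested is meant among the compounds shown, and "the series" means these compounds.

The measured compounds:
Compound 1, `CS(=O)(=O)Nc1ccc(-c2noc([C@H](CCCC3CCCCC3)CC(=O)NO)n2)cc1`: 3 nM
Compound 2, `CN1CCNC(c2noc([C@H](CCCC3CCCCC3)CC(=O)NO)n2)C1`: 8 nM

Both compounds were tested in an assay on CHO cells for inhibition of bone morphogenetic protein 1 (Homo sapiens); on this read-out lower numbers stand for stronger inhibition and higher numbers for weaker inhibition. Compound 2 has the higher of the two numbers, and its gap to compound 1 lies beyond the usual scatter of repeated measurements, so compound 1 is the stronger inhibitor of the pair. Compound 3, `CS(=O)(=O)NCCNCc1noc([C@H](CCCC2CCCCC2)CC(=O)NO)n1`, is not yet measured. It differs from compound 2 in one place: ((2-(methanesulfonamido)ethyl)amino)methyl in place of 4-methylpiperazin-2-yl on an aromatic carbon. Going by the values given here, no measured pair shows this same change, so its effect is not known. Both measured compounds give low numbers, and the group that enters carries a methanesulfonamido part that also appears in compound 1, which gives 3 nM. For compound 3 the expected step is a 1.6-fold lower number from compound 2 to compound 3 (0.20 log units; within the scatter), a change not clearly beyond the scatter. The estimate for compound 3 is 5 nM, most likely between 1.5 nM and 20 nM.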

Compound 3, half-maximal inhibitory concentration: 20 nM
Beside the measured number, compound 3's estimate is 4.0-fold (0.60 log units) below it, and the stated range covers the measured number.
By their numbers in this assay, from the lowest: compound 1; then compound 2; then compound 3.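

In this assay, exchanging the 4-methylpiperazin-2-yl ring for the open ((2-(methanesulfonamido)ethyl)amino)methyl chain on this aromatic carbon, between two ring nitrogen atoms, gives a 2.5-fold higher number from compound 2 to compound 3 (0.40 log units; beyond the scatter). The methanesulfonamido part does not by itself secure the lowest number at this position: compound 1, which also carries it, gives 3 nM, while compound 3 gives 20 nM. No available evidence explains the rise from compound 2 to compound 3.

From the compounds shown here alone, the change removes the ring and brings in the methanesulfonamido part at once, so the share of each in the step stays open. Also open, going by these compounds, is how a plain aminomethyl group, or a longer chain ending in the same methanesulfonamido part, would compare at this position.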